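The compounds below may be only part of what the source reports. "The series", "measured", "known", "first", "only" and "open" are said of these compounds alone.

Compound 1 `Cn1c(-c2ccccc2Br)cc2cc(CCC(=O)O)ccc21`: > 10000 nM
Compound 2 `CC(C)c1ccccc1-c1cc2cc(CCC(=O)O)ccc2[nH]1`: > 25 nM
Compound 3 `COc1cccc(-c2cc3cc(CCC(=O)O)ccc3[nH]2)c1`: > 25 nM

All three share one core and were tested in a functional assay on CHO cells for agonist activity at Free fatty acid receptor 1 (Homo sapiens), read by a luciferase reporter, with a stated time of 24 h; on this read-out higher numbers stand for an effect only at larger amounts of compound and lower numbers for an effect already at smaller amounts. Compound 1 sits at the limit of > 10000 nM in this assay, at which 1 of the 3 values shown sits, a limit of the assay rather than a number. Going by these compounds, compound 2 sits at the limit of > 25 nM in this assay, at which 2 of the 3 values shown sit, again a limit and not a number, so its true place is unknown beyond that. Compound 3 sits at the same limit.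

Compound 4 `COc1ccccc1-c1cc2cc(CCC(=O)O)ccc2[nH]1` differs from compound 2 by methoxy in place of isopropyl on an aromatic carbon. Going by the values given here, no measured pair shows such a step, so no size or direction can be read from the numbers; the step from compound 2 to compound 4 is expected to stay within the scatter, a step that the limit leaves unreadable from compound 2 to compound 4. Compound 4 is expected to give about 40 nM, between 8 nM and 300 nM in this assay.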

Compound 4, half-maximal effective concentration: > 25 nM
Compound 4: no number, only a limit; the forecaster's own chance of this, stated with the estimate: 50%; the middle value does not contradict the limit.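

Compound 2 and compound 4 each give only a limit, not a number, so no step can be read between them. Going by these compounds, whether isopropyl or methoxy allows an effect at smaller amounts remains open.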